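From a Benzothiophenyl Arm to a Pyrrolyl Carbonyl

The compounds below may be only part of what the source reports. "The series", "measured", "known", "first", "only" and "open" are said of these compounds alone.

Compound 1 `Clc1ccc2sc(CN3CCN(c4ncnc5c4CN(Cc4ccccc4)CC5)CC3)cc2c1` gives 2% in an assay on isolated protein for inhibition of RAC-alpha serine/threonine-protein kinase (Homo sapiens), read by HTRF, tested at 10 uM; a higher number here means more inhibition at the concentration tested (going by the name of the read-out), a lower number less inhibition.
Compound 2 `O=C(CN1CCN(c2ncnc3c2CN(Cc2ccccc2)CC3)CC1)Nc1cc(F)ccc1F` gives 0% in this assay.

Among the compounds with values here, compound 1 stands at the top of these two numbers, but compound 2 is the only neighbour and the move a number 2 percentage points lower from compound 1 to compound 2 (within the scatter) lies within the scatter, so neither compound shows any inhibition worth the name. Compound 3 `Cc1cc(C(=O)N2CCN(c3ncnc4c3CN(Cc3ccccc3)CC4)CC2)c(C)n1C` carries the change ((1,2,5-trimethyl-1H-pyrrol-3-yl)carbonyl in place of (5-chloro-1-benzothiophen-2-yl)methyl on an amine nitrogen in a ring). Within the data shown here, the one measured step that bears on it is the exchange from compound 1 to compound 2, which also removed the (5-chloro-1-benzothiophen-2-yl)methyl arm in favour of a group holding a carbonyl and moved the read-out by a number 2 percentage points lower from compound 1 to compound 2 (within the scatter), nothing beyond the scatter. The same behaviour is therefore expected here, and the step of a number 1 percentage points lower from compound 1 to compound 3 (within the scatter) is estimated to stay within the scatter. In this assay compound 3 is expected to give about 1%, with a range from -8% to 12%.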

Compound 3, a percentage reported as inhibition, at one concentration (the size of the read-out at that concentration, not a potency): 0%
Compound 3: the middle estimate sits 1 percentage points above what was measured; the range from low to high includes it.
By their numbers in this assay, from the lowest: compounds 2, 3 and 1 (each within the scatter of the next).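

In this assay, putting the (1,2,5-trimethyl-1H-pyrrol-3-yl)carbonyl group on the amine nitrogen in a ring in place of the (5-chloro-1-benzothiophen-2-yl)methyl arm gives a number 2 percentage points lower from compound 1 to compound 3 (within the scatter). This change places a carbonyl on that ring nitrogen itself and removes the six-membered aromatic ring of carbon only, yet compound 3 still gives 0%, so neither feature of the change separates it from compound 1 in this read-out. Nothing available explains this flat result.

The compounds shown leave open whether any group on this nitrogen can lift the number clear of the scatter, such as a chain ending in a primary amine or a carboxylic acid. They also leave open whether changes elsewhere on the shared core would do so.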